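Shortening the phenylalkyl chain on a crown-ether ester

The source may report more compounds than this note shows. Statements on the series, on what has been measured and on what is new or still open speak of the compounds shown alone.

Compounds measured so far:
- compound 1, `O=C(CCCCCc1ccccc1)OCC1COCCOCCOCCOCCOCCO1`, 64000 nM
- compound 2, `CC(=O)OCC1COCCOCCOCCOCCOCCO1`, > 100000 nM
- compound 3, `O=C(CCCc1cc2ccccc2[nH]1)OCC1COCCOCCOCCOCCOCCO1`, > 100000 nM

All three share one core, an ester on a crown-ether ring, and were tested in a functional assay on HBL-100 cells (Homo sapiens) for inhibition, read by sulforhodamine B assay, with a stated time of 48 h; a lower number here means a stronger inhibitor of growth, a higher number a weaker inhibitor of growth. Within the data shown here, compound 1 gives 64000 nM, the only actual number in the set. Compound 2 is reported only as a limit of the assay, > 100000 nM. Compound 3 likewise is reported only as a limit, > 100000 nM. The steps of an at least 1.5-fold higher number from compound 1 to compound 2 (0.19 log units; that floor lies within the scatter) and an at least 1.5-fold higher number from compound 1 to compound 3 (0.19 log units; that floor lies within the scatter) therefore have floors that lie within the scatter, and the step that the two limits leave unreadable from compound 2 to compound 3 cannot be read; see (the limit of > 100000 nM in this assay, at which 2 of the 3 values shown sit).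

Compound 4, `O=C(CCCCc1ccccc1)OCC1COCCOCCOCCOCCOCCO1`, differs from compound 1 by phenyl in place of benzyl on a saturated chain carbon, four bonds along the chain from a carbonyl carbon. Among the measured compounds shown here, no measured step changes the length of this chain alone, so no direction can be read from the data; the only guidance is that losing the chain entirely, as in compound 2, moves the value to the limit. A step in this assay of about a 1.4-fold higher number from compound 1 to compound 4 (0.15 log units; within the scatter) is expected, close to no change beyond the scatter. Compound 4 is estimated at 90000 nM, within 40000 nM to 200000 nM.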

Compound 4, concentration for 50% growth inhibition: 69000 nM
Estimate against measurement, compound 4: 1.3-fold (0.12 log units) above, within the range that was stated.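

Phenyl in place of benzyl, four bonds along the chain from a carbonyl carbon, is the same difference as 4-phenylbutyl to 3-phenylpropyl, and it is the first step here that changes only the length of this chain with a real number at both ends. In this assay that step is a 1.1-fold higher number from compound 1 to compound 4 (0.03 log units; within the scatter), so these two chain lengths cannot be told apart, and this position tolerates the change without a visible loss of growth inhibition. The other two steps are an at least 1.4-fold lower number from compound 3 to compound 4 (0.16 log units; that floor lies within the scatter) and an at least 1.4-fold lower number from compound 2 to compound 4 (0.16 log units; that floor lies within the scatter), and neither can be taken as a real difference, because each has only a floor, set by the assay limit, that lies within the scatter: the limit of > 100000 nM in this assay, at which 2 of the 4 values shown sit.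

The compounds shown leave open how far the chain can shrink or grow before the value moves, since benzyl or phenethyl in place of the 3-phenylpropyl group, or a chain longer than 4-phenylbutyl, would test both directions. They also leave open whether an amine or a carboxylic acid at the chain end, or a fluorine on the phenyl ring, would bring a number clearly lower than those of compound 1 and compound 4.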